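This account rests on a few compounds, and the source may have more. Where it says the series, first, only, none or still open, it means among the compounds named here.

Compound 3 `CC(C)c1c(C(=O)N(C)Cc2cccc(Cl)c2)nn(-c2ccc(F)cc2)c1OC[C@@H](O)C[C@@H](O)CC(=O)O` gives 8.3 nM in an assay on microsomes from liver for inhibition of 3-hydroxy-3-methylglutaryl-coenzyme A reductase (Rattus norvegicus) (on this read-out higher numbers stand for weaker inhibition and lower numbers for stronger inhibition), the highest number among the three compounds measured, although its gap to compound 2 is within the scatter. Compound 1 `CC(C)c1c(C(=O)NCc2ccccc2)nn(-c2ccc(F)cc2)c1OC[C@@H](O)C[C@@H](O)CC(=O)O` gives 3.8 nM in this assay, and compound 2 `CC(C)c1c(C(=O)NCc2ccc(Cl)cc2)nn(-c2ccc(F)cc2)c1OC[C@@H](O)C[C@@H](O)CC(=O)O` gives 6.7 nM. The step of a 2.2-fold higher number from compound 1 to compound 3 (0.34 log units; beyond the scatter) is modest, whereas a 1.8-fold higher number from compound 1 to compound 2 (0.25 log units; within the scatter) and a 1.2-fold higher number from compound 2 to compound 3 (0.09 log units; within the scatter) stay within the scatter. Compound 4 `COc1cccc(CN(C)C(=O)c2nn(-c3ccc(F)cc3)c(OC[C@@H](O)C[C@@H](O)CC(=O)O)c2C(C)C)c1` differs from compound 3 by methoxy in place of chloro on an aromatic carbon. For the measured compounds named here, no measured step swaps one substituent on this ring for another; the steps that touch this ring were all small. The expected step is therefore a 1.1-fold higher number from compound 3 to compound 4 (0.04 log units; within the scatter), nothing beyond the scatter. Compound 4 is estimated at 9 nM, with a range from 4 nM to 22 nM.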

Compound 4, half-maximal inhibitory concentration: 21 nM
Compound 4: the middle estimate sits 2.3-fold (0.37 log units) below what was measured; measured number inside the range.
By their numbers in this assay, from the lowest: compounds 1, 2 and 3 (each within the scatter of the next, the first and the last beyond it); then compound 4.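

In this assay, for the compounds shown here, methoxy in place of chloro gives a 2.5-fold higher number from compound 3 to compound 4 (0.40 log units; beyond the scatter) and is the first swap of one substituent for another on this ring, showing that the number at this position can move beyond the scatter. The other comparisons give a 3.1-fold higher number from compound 2 to compound 4 (0.50 log units; beyond the scatter) and a 5.5-fold higher number from compound 1 to compound 4 (0.74 log units; beyond the scatter) and place compound 4 highest of the four. No measurement shown here accounts for the rise with methoxy. Still open, on these data alone, is where a hydroxy group, an amine or a longer chain such as ethoxy would fall at this position, and whether methoxy gives a similar step when the amide hydrogen replaces the methyl.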